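Swapping the Oxetane Amide for a Methyl Amide

The source may report more compounds than this note shows. Statements on the series, on what has been measured and on what is new or still open speak of the compounds shown alone.

Compound 1 `CNC(=O)c1cc(-n2ncc3cc(Nc4ccccc4Cl)c(F)cc32)cs1` gives 0.7 h in an ADME assay on microsomes from liver (Mus musculus) for metabolic stability; a lower number here means that the compound disappears faster, a higher number that the compound lasts longer. Compound 2 `O=C(NC1COC1)c1cc(-n2ncc3cc(Nc4ccccc4Cl)cnc32)cs1` gives 0.15 h. Compound 3 `CNC(=O)c1cc(-n2ncc3cc(Nc4c(F)cccc4Cl)c(C)nc32)cs1` gives 0.283 h.

Among these three, compound 2 sits at the low end of the numbers: its gap to compound 3 lies within the scatter, whereas compound 1 lies beyond it. Compound 4 `CNC(=O)c1cc(-n2ncc3cc(Nc4ccccc4Cl)cnc32)cs1` is the still unmeasured partner of compound 2, differing from it only by methyl in place of oxetan-3-yl on an amide-type nitrogen. For the measured compounds named here, no measured pair isolates this change, so its size can only be estimated. Compound 1 and compound 3 both carry the methylcarbamoyl group, and their numbers sit around or above that of compound 2, so a modest rise in this assay is expected, without certainty that it clears the scatter. For compound 4 the estimate is 0.3 h, with a range from 0.12 h to 0.8 h, which would mean an expected step of a 2.0-fold higher number from compound 2 to compound 4 (0.30 log units; within the scatter).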

Compound 4, half-life: 0.233 h
The estimate for compound 4 lay 1.3-fold (0.11 log units) above the measured number, within the range that was stated.
By their numbers in this assay, from the lowest: compounds 2, 4 and 3 (each within the scatter of the next); then compound 1.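

In this assay, putting methyl in place of oxetan-3-yl on the amide-type nitrogen gives a 1.6-fold higher number from compound 2 to compound 4 (0.19 log units; within the scatter). For the compounds shown here, this pair is the first to isolate the change, and it shows that the four-membered ring and its oxygen can give way to a single carbon at this position without a step beyond the scatter. No measurement at hand bears on the reason for this result.

As far as these compounds go, whether the swap behaves the same way on the cores of compound 1 and compound 3 remains open. So does the effect of an ethyl group or a longer chain carrying an amine on this nitrogen.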